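The source may hold more compounds than are shown below. What is called first, only, known or untested is meant among the compounds shown, and "the series" means these compounds.

The measured compounds are these: compound 1, `CCCCOc1ccc(C(=O)NNC(=O)c2ccc(NS(=O)(=O)c3cnc(O)nc3O)cc2)cc1`, which in a functional assay on MDA-MB-231 cells (Homo sapiens) for antiproliferative activity, read by MTT assay, with a stated time of 24 h (on this read-out higher numbers stand for weaker inhibition and lower numbers for stronger inhibition), gives 11900 nM; compound 2, `Cc1ccccc1C(=O)NNC(=O)c1ccc(NS(=O)(=O)c2cnc(O)nc2O)cc1`, which in this assay gives 7040 nM; and compound 3, `CCCCOc1ccc(C(=O)NNC(=O)c2ccccc2NS(=O)(=O)c2cnc(O)nc2O)cc1`, which in this assay gives 6830 nM. Compound 4, `Cc1ccccc1C(=O)NNC(=O)c1ccccc1NS(=O)(=O)c1cnc(O)nc1O`, has not yet been measured.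

Compound 2 arises from compound 1 by one change: 2-methylphenyl in place of 4-butoxyphenyl on a carbonyl carbon. The step it made was a 1.7-fold lower number from compound 1 to compound 2 (0.23 log units; within the scatter). Compound 3 has the same atoms as compound 1, joined differently; the difference between the two cores is not broken down here. The values of compound 2 and compound 3 in this assay lie close to one another.

Compound 4 arises from compound 3 by the same change: 2-methylphenyl in place of 4-butoxyphenyl on a carbonyl carbon. The surroundings of the place where the change is made read the same in both pairs, so this is the same change and not merely one of the same kind. Whether the step repeats on the core of compound 3 rests on a single earlier example, and that earlier step was small. Because the earlier step was a 1.7-fold lower number from compound 1 to compound 2 (0.23 log units; within the scatter), compound 4 is expected to show a step of about a 1.5-fold lower number from compound 3 to compound 4 (0.18 log units; within the scatter) in this assay. The estimate for compound 4 is 4500 nM, expected to lie between 2000 nM and 10000 nM.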

Compound 4, half-maximal inhibitory concentration: 5570 nM
Compound 4: middle estimate off by 1.2-fold (0.09 log units), on the low side, within the range that was stated.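

In this assay, replacing 4-butoxyphenyl with 2-methylphenyl on the core of compound 3 gave a 1.2-fold lower number from compound 3 to compound 4 (0.09 log units; within the scatter), and this step can be set directly beside the earlier one on the core of compound 1: the same change on two cores in this assay, a 1.7-fold lower number (0.23 log units; within the scatter) from compound 1 to compound 2 and a 1.2-fold lower number (0.09 log units; within the scatter) from compound 3 to compound 4, 1.4-fold (0.14 log units) apart, within the scatter of two such steps The two cores therefore give no sign that this change behaves differently from one to the other, and the direction of the printed step is the same in both pairs. Among the compounds shown here, this does not show that the change has a real effect that carries over, as each step lies within the scatter and so cannot be told apart from repeated measurement of a single compound, and the comparison rests on only two pairs.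

The compounds shown leave open whether a group of another kind on the carbonyl carbon, such as an amine, a carboxylic acid or a longer alkoxy chain in place of the butoxy chain, would produce a step large enough to stand clear of the scatter. For the compounds shown here, they also leave open whether the agreement seen here would hold on a third core, since only two cores carry this change.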